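The compounds below may be only part of what the source reports. "The series", "measured", "known", "first", "only" and "open" are said of these compounds alone.

Measured so far in an ADME assay on HeLa Rh cells (Homo sapiens) for cytotoxicity, read by microscopy; a higher number here means that more compound is tolerated, a lower number that less compound is tolerated:
compound 1 `COc1cc(CC(O)c2ccc(-c3ccc(C#N)cc3)cc2)c([N+](=O)[O-])cc1OC` gives 4700 nM;
compound 2 `COc1cc(CC(O)c2ccc(-c3ccc(Cl)cc3)cc2)c([N+](=O)[O-])cc1OC` gives 4100 nM;
compound 3 `COc1cc(CC(O)c2ccc(-c3cccc(CO)c3)cc2)c([N+](=O)[O-])cc1OC` gives 6000 nM.

Compound 3 is not set apart from the other two: a 1.3-fold higher number from compound 1 to compound 3 (0.11 log units; within the scatter) and a 1.5-fold higher number from compound 2 to compound 3 (0.17 log units; within the scatter) both fall within the scatter, as does a 1.1-fold lower number from compound 1 to compound 2 (0.06 log units; within the scatter). Compound 4 `COc1cc(CC(O)c2ccc(-c3ccccc3[N+](=O)[O-])cc2)c([N+](=O)[O-])cc1OC` differs from compound 3 by 2-nitrophenyl in place of 3-(hydroxymethyl)phenyl on an aromatic carbon. The two measured steps that exchanged the group at this same place, those ending at compound 3, moved nothing beyond the scatter, so no step beyond the scatter is expected in this assay for this exchange either. Compound 4 is therefore expected to give about 5000 nM, within a range of 2500 nM to 10000 nM. That estimate means a step of a 1.2-fold lower number from compound 3 to compound 4 (0.08 log units; within the scatter), expected to stay inside the scatter.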

Compound 4, half-maximal cytotoxic concentration: 9500 nM
Estimate against measurement, compound 4: 1.9-fold (0.28 log units) below; low and high end bracket the measured number.
By their numbers in this assay, from the lowest: compounds 2, 1, 3 and 4 (each within the scatter of the next, the first and the last beyond it).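

In this assay, among these compounds, exchanges at this place on an aromatic carbon now reach beyond the scatter, which none of the earlier steps did: 2-nitrophenyl brings a 2.3-fold higher number from compound 2 to compound 4 (0.36 log units; beyond the scatter) in place of 4-chlorophenyl and a 2.0-fold higher number from compound 1 to compound 4 (0.31 log units; beyond the scatter) in place of 4-cyanophenyl. In place of 3-(hydroxymethyl)phenyl it brings a 1.6-fold higher number from compound 3 to compound 4 (0.20 log units; within the scatter) and stays within the scatter. The number therefore responds to the group at this place, but only modestly across these four compounds. Nothing available here bears on the cause of these steps.

On these data alone, whether the step depends on the nitro group itself remains open, as does the outcome with an amine or a carboxylic acid on this aromatic ring.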